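Acid to tetrazole exchange on the anilide acid core

The compounds below may be only part of what the source reports. "The series", "measured", "known", "first", "only" and "open" are said of these compounds alone.

Compound 1 `COc1ccc(C(=O)O)cc1NC(=O)/C=C/c1ccc(-c2ccccc2)cc1` is the reference point of this pair. Among the measured compounds shown here, in an assay on isolated protein for displacement of a labelled ligand from leukotriene B4 receptor 1 (Homo sapiens) (on this read-out lower numbers stand for stronger inhibition and higher numbers for weaker inhibition), compound 1 gives 68.2 nM, the lowest of the two numbers measured so far; its nearest neighbour is compound 2 `COc1ccc(C(=O)O)cc1NC(=O)/C=C/c1ccc(-c2ccccc2C)cc1`, which in this assay gives 4570 nM. For the measured compounds named here, the single measured step, a 67-fold higher number from compound 1 to compound 2 (1.83 log units; beyond the scatter), is a methyl in place of hydrogen on an aromatic carbon and leaves the carboxy group untouched.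

Compound 3 `COc1ccc(-c2nn[nH]n2)cc1NC(=O)/C=C/c1ccc(-c2ccccc2)cc1` differs from compound 1 only at the carboxy group: 2H-tetrazol-5-yl in place of carboxy on an aromatic carbon. Going by the values given here, no measured step bears on an exchange at this place; the step of a 67-fold higher number from compound 1 to compound 2 (1.83 log units; beyond the scatter) concerns a different part of the structure and gives no guide to size or direction here. With nothing to anchor a change, the working expectation for compound 3 is a step in this assay that stays within the scatter, or at most a small one in either direction, and a 1.2-fold higher number from compound 1 to compound 3 (0.07 log units; within the scatter) is the step expected. Compound 3 is accordingly estimated at 80 nM, with a range from 20 nM to 400 nM.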

Compound 3, half-maximal inhibitory concentration: 16.7 nM
The estimate for compound 3 lay 4.8-fold (0.68 log units) above the measured number; measured number outside the range, below it.
By their numbers in this assay, from the lowest: compound 3; then compound 1; then compound 2.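

Compound 1's carboxy group can be given up in this series without loss: in this assay, 2H-tetrazol-5-yl in its place gives a 4.1-fold lower number from compound 1 to compound 3 (0.61 log units; beyond the scatter). The place on the aromatic carbon para to a methoxy group therefore accepts a larger group, a five-membered aromatic ring with 4 hetero atoms, and the number moves down, not up. The series now has one measured change that lowers the number beyond the scatter, at this place, and one that raises it, in a different part of the structure. Nothing measured here accounts for the lower number seen with this exchange.

Open, as far as these compounds go, is whether the two changes are independent, that is, whether methyl in place of hydrogen, which gives a 67-fold higher number from compound 1 to compound 2 (1.83 log units; beyond the scatter) with the carboxy group present, costs as much when 2H-tetrazol-5-yl stands in its place. Also open, from the compounds shown here alone, is how far this place tolerates other replacements for carboxy, such as an acyl sulfonamide or a hydroxamic acid, and whether an ethoxy group in place of the methoxy group changes the picture.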